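Hydroxamate chain length and aryl swap on a shared core

The source may hold more compounds than are shown below. What is called first, only, known or untested is meant among the compounds shown, and "the series" means these compounds.

Measured compounds:
Compound 1, `Nc1ncnc2c1c(-c1cnc3[nH]ccc3c1)nn2CCCC(=O)NO`: > 50000 nM in a functional assay on HepG2 cells (Homo sapiens) for inhibition, read by MTT assay, with a stated time of 72 h; on this read-out lower numbers stand for stronger inhibition and higher numbers for weaker inhibition
Compound 2, `Nc1nc2cc(-c3nn(CCCCCC(=O)NO)c4ncnc(N)c34)ccc2o1`: 1990 nM
Compound 3, `Nc1nc2cc(-c3nn(CCCCCCCCCC(=O)NO)c4ncnc(N)c34)ccc2o1`: 28600 nM

The value given for compound 1 is a limit of this assay, not a number. Among the numbers shown, compound 3 stands highest; its nearest neighbour is compound 2, and the step of a 14-fold higher number from compound 2 to compound 3 (1.16 log units; beyond the scatter) lies beyond the scatter, so the longer chain of compound 3 weakened inhibition clearly.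

Compound 4, `Nc1ncnc2c1c(-c1cnc3[nH]ccc3c1)nn2CCCCCCCCCC(=O)NO`, keeps the long chain of compound 3 and differs from it at the aryl group: a group of 9 heavy atoms (7 carbon, 2 nitrogen; one five-membered aromatic ring with 1 hetero atom, one six-membered aromatic ring with 1 hetero atom) in place of a group of 10 heavy atoms (7 carbon, 2 nitrogen, 1 oxygen; one five-membered aromatic ring with 2 hetero atoms, one six-membered aromatic ring of carbon only), on an aromatic carbon. For the measured compounds named here, no measured pair isolates this aryl change, so no step bears directly on it. Going by the values given here, the only compound carrying the same aryl group as compound 4 is compound 1, and that sits at the limit (the limit of > 50000 nM in this assay, at which 1 of the 3 values shown sits), but compound 1 also carries a far shorter chain, so the two values show only that this aryl group has not yet given a measurable number.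

Compound 4 is therefore expected to stay near or somewhat above compound 3, with the step of a 1.4-fold higher number from compound 3 to compound 4 (0.15 log units; within the scatter) estimated as modest and uncertain. The estimate for compound 4 in this assay is 40000 nM, within 12000 nM to 130000 nM.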

Compound 4, half-maximal inhibitory concentration: 11700 nM
Compound 4: middle estimate off by 3.4-fold (0.53 log units), on the high side; the measured number lies below the stated range.
By their numbers in this assay, from the lowest: compound 2; then compound 4; then compound 3. At a limit, above all of these: compound 1.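

In this assay, the aryl position on the shared core accepts the group that replaces 2-amino-1,3-benzoxazol-5-yl, and on the long chain this swap gives a 2.4-fold lower number from compound 3 to compound 4 (0.39 log units; beyond the scatter), so the earlier limit did not reflect this aryl group alone. With that aryl group held fixed, lengthening the chain gives an at least 4.2-fold lower number from compound 1 to compound 4 (0.63 log units; beyond the scatter), opposite in direction to a 14-fold higher number from compound 2 to compound 3 (1.16 log units; beyond the scatter), although the two pairs do not span the same chain lengths. The value of compound 1 is a limit, not a number: the limit of > 50000 nM in this assay, at which 1 of the 4 values shown sits.

On these data alone, how the aryl group of compound 4 behaves on the intermediate chain of compound 2 remains open, so the two aryl groups cannot yet be compared at any shorter chain length. Also open, as far as these compounds go, is whether a carboxylic acid could take the place of the hydroxycarbamoyl end on either aryl series.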